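Swapping chloro for amino on a purine core

The source may report more compounds than this note shows. Statements on the series, on what has been measured and on what is new or still open speak of the compounds shown alone.

Compound 1, `Nc1nc(Cl)c2ncn(Cc3ccc(CCl)cc3)c2n1`, gives > 100000 nM in a functional assay on MOLT-4 cells (Homo sapiens) for cytotoxicity, read by sulforhodamine B assay, with a stated time of 48 h; on this read-out lower numbers stand for higher toxicity in this test and higher numbers for lower toxicity in this test; this is a limit of the assay, not a number.
Compound 2, `ClCc1cccc(Cn2cnc3c(Cl)nc(Cl)nc32)c1`, gives > 100000 nM; this too is a limit, not a number.
Compound 3, `ClCc1ccc(Cn2cnc3c(Cl)nc(Cl)nc32)cc1`, gives 72400 nM.

Compound 3 and compound 1 carry the same side chain and differ in one place: amino in place of chloro on an aromatic carbon. That single change produced an at least 1.3-fold higher number from compound 3 to compound 1 (0.14 log units; that floor lies within the scatter), so the amino compound is no more toxic than the dichloro one within what the assay can resolve. The difference between the core of compound 2 and the core of compound 3 is not broken down here; the two have the same atoms joined differently.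

Compound 4, `Nc1nc(Cl)c2ncn(Cc3cccc(CCl)c3)c2n1`, has not yet been measured in this assay. It stands to compound 2 exactly as compound 1 stands to compound 3: amino in place of chloro on an aromatic carbon, the same change at the same place. Two of the three known values sit at the limit of > 100000 nM in this assay, at which 2 of the 3 values shown sit, and compound 2 is one of them. Because compound 2 already rests at the limit of > 100000 nM in this assay, at which 2 of the 3 values shown sit, and the same change elsewhere did not push toxicity upward, compound 4 is expected to remain at that ceiling, an expected step that the limit leaves unreadable from compound 2 to compound 4. Compound 4 is thus estimated at 150000 nM, with a likely range from 80000 nM to 400000 nM, and most probably reported only as a limit.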

Compound 4, concentration lethal to 50% of the cells: > 100000 nM
Compound 4 gave a limit, no number; the forecaster's own chance of this, stated with the estimate: 85%; the middle value does not contradict the limit.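

No step can be read from compound 2 to compound 4 in this assay because neither compound gives a number, only a limit: the limit of > 100000 nM in this assay, at which 3 of the 4 values shown sit.

The compounds shown leave open whether amino in place of chloro on an aromatic carbon changes the toxicity of this pair at all, and whether the size of that change matches the one seen from compound 3 to compound 1.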